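Swapping a branched amine chain for a straight one

A few compounds are considered here, and "the series" means these few. Any claim that something is new, unique, unknown or untested is made for them only; others in the source may bear on it.

Measured in an ADME assay on the whole organism (strain FVB) for pharmacokinetics, with Mus musculus as the target, read by LC-MS, at a dose of 30 mg/kg by the oral route; on this read-out lower numbers stand for lower exposure and higher numbers for higher exposure at the dose given
- Compound 1 `CC(C)(O)CN1CCC(Oc2ccc([C@H]3CC[C@]4(CC3)OOC3(O4)C4CC5CC(C4)CC3C5)cc2)CC1` gives 1810 nM
- Compound 2 `c1cc([C@H]2CC[C@]3(CC2)OOC2(O3)C3CC4CC(C3)CC2C4)ccc1OCCC1CCNCC1` gives 1190 nM
- Compound 3 `CC(C)(CN)Oc1ccc([C@H]2CC[C@]3(CC2)OOC2(O3)C3CC4CC(C3)CC2C4)cc1` gives 529 nM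

Compound 3 stands lowest of the three in this assay, at 529 nM. The next compound is compound 4 `NCCCCOc1ccc([C@H]2CC[C@]3(CC2)OOC2(O3)C3CC4CC(C3)CC2C4)cc1`, which keeps the same atoms but joins them differently: 4-aminobutyl in place of 1-(aminomethyl)-1-methylethyl on an oxygen on an aromatic ring. In plain words, 4-aminobutyl replaces 1-(aminomethyl)-1-methylethyl on an oxygen on an aromatic ring.

Three measured steps change the group on that same oxygen. There is a 3.4-fold lower number from compound 1 to compound 3 (0.53 log units; beyond the scatter) and a 2.2-fold lower number from compound 2 to compound 3 (0.35 log units; beyond the scatter), both modest, while a 1.5-fold lower number from compound 1 to compound 2 (0.18 log units; within the scatter) stays within the scatter. None of them compares these two particular chains, so they indicate a plausible size but no direction. A change between two chains of equal atom count is therefore not expected to move the number beyond the scatter. The expected result is a 1.1-fold higher number from compound 3 to compound 4 (0.05 log units; within the scatter). For compound 4 the estimated value is 600 nM, with an expected range of 200 nM to 1700 nM.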

Compound 4, maximal plasma concentration: 370 nM
Beside the measured number, compound 4's estimate is 1.6-fold (0.21 log units) above it; the measured number falls inside the stated range.
By their numbers in this assay, from the lowest: compounds 4 and 3 (each within the scatter of the next); then compounds 2 and 1 (each within the scatter of the next).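

In this assay the rearranged chain gives a 1.4-fold lower number from compound 3 to compound 4 (0.16 log units; within the scatter), so joining the same atoms as a straight 4-aminobutyl rather than a branched 1-(aminomethyl)-1-methylethyl makes no difference that can be read on this oxygen on an aromatic ring. The straight chain also sits clearly under both groups that contain a piperidin-4-yl, with a 3.2-fold lower number from compound 2 to compound 4 (0.51 log units; beyond the scatter) and a 4.9-fold lower number from compound 1 to compound 4 (0.69 log units; beyond the scatter), so compound 3 and compound 4 together form a lower pair whichever of the two chains is present. No measured evidence accounts for this gap between the pair and the piperidine-bearing compounds.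

Still open, on these data alone, is whether a longer chain such as 5-aminopentyl would stay in that lower pair or move towards compound 2. As far as these compounds go, it is also open how a carboxylic acid in place of the amine would behave at the end of the chain.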